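A few compounds are considered here, and "the series" means these few. Any claim that something is new, unique, unknown or untested is made for them only; others in the source may bear on it.

Compound 2 `O=S(=O)(Nc1cccc2ccccc12)c1ccc2nc(-c3ccccc3)c(-c3ccccc3)nc2c1` stands level with compound 1 `COc1ccccc1NS(=O)(=O)c1ccc2nc(-c3ccccc3)c(-c3ccccc3)nc2c1`: in an ADME assay on the whole organism for pharmacokinetics, with Homo sapiens as the target (a lower number here means that a smaller share of the oral dose reaches the circulation, a higher number that a larger share of the oral dose reaches the circulation), compound 1 gives 100%, and compound 2 gives 100%. For the measured compounds named here, the only measured step, no change at the digits printed from compound 1 to compound 2 (within the scatter), left that number where it was. The change now considered is 3-acetylphenyl in place of naphthalen-1-yl on a sulfonamide nitrogen, which gives compound 3 `CC(=O)c1cccc(NS(=O)(=O)c2ccc3nc(-c4ccccc4)c(-c4ccccc4)nc3c2)c1`. The earlier step bears on it in that it also exchanged the group on the sulfonamide nitrogen, and that step was flat, so compound 3 is expected to show a step of a number 5 percentage points lower from compound 2 to compound 3 (within the scatter), nothing beyond the scatter. The estimate for compound 3 in this assay is 95%, between 75% and 100%.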

Compound 3, oral bioavailability: 96.9%
Beside the measured number, compound 3's estimate is 1.9 percentage points below it, and the stated range covers the measured number.
By their numbers in this assay, from the lowest: compounds 3, 1 and 2 (each within the scatter of the next).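

With 3-acetylphenyl on the sulfonamide nitrogen, this assay shows a number 3.1 percentage points lower from compound 2 to compound 3 (within the scatter) and a number 3.1 percentage points lower from compound 1 to compound 3 (within the scatter). This position therefore also accepts a single aromatic ring bearing an acetyl carbonyl, which adds a hydrogen-bond acceptor that neither naphthalen-1-yl nor the earlier step had brought in this way, and all three groups stay within the scatter of one another. Nothing available explains this flat result. As far as these compounds go, whether an aminophenyl or carboxyphenyl group on this nitrogen would stay level remains open. So does the outcome for a longer alkyl chain in place of the aromatic ring.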